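The source may hold more compounds than are shown below. What is called first, only, known or untested is meant among the compounds shown, and "the series" means these compounds.

Measured compounds in hand:

compound 1, `COc1ccc(CNCCCNS(=O)(=O)c2cc(C(F)(F)F)cc(C(F)(F)F)c2)cc1OC`: 3600 nM
compound 2, `O=S(=O)(NCCCNCc1cccc2ccccc12)c1cc(C(F)(F)F)cc(C(F)(F)F)c1`: 2700 nM
compound 3, `O=S(=O)(NCCCNCc1ccc(-c2ccccc2)cc1)c1cc(C(F)(F)F)cc(C(F)(F)F)c1`: 2600 nM

In a functional assay on BE(2)-C cells (Homo sapiens) for inhibition, read by MTT assay, with a stated time of 72 h (a lower number here means a stronger inhibitor of growth, a higher number a weaker inhibitor of growth), compound 1 stands at the highest of the three numbers, but the spread of the set is small. Among the measured compounds shown here, the one step recorded from it, a 1.3-fold lower number from compound 1 to compound 2 (0.12 log units; within the scatter), lies within the scatter. For the measured compounds named here, for compound 3 no step is computed; its value and that of compound 1 lie within the scatter of each other, so no order among the three can be claimed.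

Compound 4, `COc1ccc(CNCCCNS(=O)(=O)c2cc(C(F)(F)F)cc(C(F)(F)F)c2)cc1`, differs from compound 1 by hydrogen in place of methoxy on an aromatic carbon. Going by the values given here, no measured step removes a single methoxy; the only step that bears on the benzyl end is the exchange of the whole 3,4-dimethoxyphenyl for naphthalen-1-yl, and that step was within the scatter. With three values all within scatter of each other, the expectation is a step of no size beyond the scatter, a 1.0-fold lower number from compound 1 to compound 4 (0.01 log units; within the scatter). Compound 4 is therefore estimated at 3500 nM, with a range of 1500 nM to 8000 nM.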

Compound 4, concentration for 50% growth inhibition: 2800 nM
Beside the measured number, compound 4's estimate is 1.3-fold (0.10 log units) above it, within the range that was stated.
By their numbers in this assay, from the lowest: compounds 3, 2, 4 and 1 (each within the scatter of the next).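

In this assay, among the compounds shown here, the single change of hydrogen in place of methoxy, on an aromatic carbon ortho to a methoxy group, gives a 1.3-fold lower number from compound 1 to compound 4 (0.11 log units; within the scatter) and so isolates this position for the first time; the step shows no readable effect of that methoxy. The 4-methoxyphenyl end also shows no readable separation from the other two aromatic ends, with a 1.1-fold higher number from compound 3 to compound 4 (0.03 log units; within the scatter) for methoxy in place of phenyl and a 1.0-fold higher number from compound 2 to compound 4 (0.02 log units; within the scatter) for 4-methoxyphenyl in place of naphthalen-1-yl. Across these steps, no order among the benzyl-end groups can be drawn.

Still open, as far as these compounds go, is whether a carboxylic acid on the aromatic ring, a longer chain in the linker, or a nitrile in place of trifluoromethyl would move the number beyond the scatter. No supporting measurement is available to interpret these close values.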